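Carboxyphenyl in place of cyanopyridyl in a bombesin receptor series

This account rests on a few compounds, and the source may have more. Where it says the series, first, only, none or still open, it means among the compounds named here.

Measured so far:
compound 1, `CCC(C)(C)Cc1c[nH]c(CCc2ccc(-c3cccc(C)n3)cc2)n1`, 6.3 nM
compound 2, `CCC(C)(C)Cc1c[nH]c(CCc2ccc(-c3cccc(C#N)n3)cc2)n1`, 140 nM

These two compounds share one core and differ only in the group on the terminal aromatic ring. Among the compounds with values here, in an in vitro assay on CHO cells for displacement of a labelled ligand from Bombesin receptor subtype-3 (Homo sapiens), read by scintillation counting, with a stated time of 2 h (on this read-out lower numbers stand for stronger inhibition and higher numbers for weaker inhibition), compound 1 gives 6.3 nM, while compound 2 gives 140 nM, the highest of the two numbers; the only measured step, a 22-fold higher number from compound 1 to compound 2 (1.35 log units; beyond the scatter), shows that a small change at this position can move the number a long way.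

Compound 3, `CCC(C)(C)Cc1c[nH]c(CCc2ccc(-c3ccccc3C(=O)O)cc2)n1`, is not yet measured. It differs from compound 2 in one place: 2-carboxyphenyl in place of 6-cyanopyridin-2-yl on an aromatic carbon. This is a larger change than the one already measured, replacing the whole cyanopyridyl group rather than one substituent on it. Within the data shown here, since the one measured step from compound 1 to compound 2 was large, a sizeable shift in this assay is to be expected, but its direction cannot be read from a single step. The estimate for compound 3 is 250 nM, within a range from 25 nM to 2500 nM, which corresponds to an expected step of a 1.8-fold higher number from compound 2 to compound 3 (0.25 log units; within the scatter).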

Compound 3, half-maximal inhibitory concentration: 11 nM
Compound 3: middle estimate off by 23-fold (1.36 log units), on the high side, and the stated range ends above it.
By their numbers in this assay, from the lowest: compounds 1 and 3 (each within the scatter of the next); then compound 2.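

In this assay, replacing the whole terminal group of compound 2 with 2-carboxyphenyl gives a 13-fold lower number from compound 2 to compound 3 (1.10 log units; beyond the scatter) and so shows that the high number of compound 2 is not fixed by the shared core: this position can also give a low number with a quite different group on it. Against compound 1, the same kind of exchange gives a 1.7-fold higher number from compound 1 to compound 3 (0.24 log units; within the scatter) and so leaves compound 1 and compound 3 indistinguishable here, even though one carries a pyridine ring with a methyl and the other a carbon-only ring with a carboxylic acid; of the three groups, only 6-cyanopyridin-2-yl stands apart. Nothing at hand explains why these groups give the numbers they do.

The compounds shown leave open whether the carboxylic acid or the carbon-only ring accounts for the result, and a plain phenyl ring, or a phenyl ring bearing a methyl ester or a primary amide instead of the acid, would separate the two. They also leave open whether a nitrile would give a high number on a carbon-only ring, as in a 2-cyanophenyl group.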